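Pyridin-2-yl in place of phenyl on an amine nitrogen

A few compounds are considered here, and "the series" means these few. Any claim that something is new, unique, unknown or untested is made for them only; others in the source may bear on it.

Two compounds in the series have readings so far. In a physicochemical assay for solubility, read by HPLC (on this read-out lower numbers stand for lower solubility and higher numbers for higher solubility), compound 1 (`COc1ccc(NC[C@H](O)COc2ccc(N3C[C@H](CNC(C)=O)OC3=O)cc2F)cc1`) gives 56000 nM as its reading. In this assay compound 2 (`CC(=O)NC[C@H]1CN(c2ccc(OC[C@H](O)CNc3ccccc3)c(F)c2)C(=O)O1`) gives 296000 nM as its reading and holds the higher of the two numbers, with a gap to compound 1 that lies beyond the scatter.

The next structure is compound 3 (`CC(=O)NC[C@H]1CN(c2ccc(OC[C@H](O)CNc3ccccn3)c(F)c2)C(=O)O1`), which carries pyridin-2-yl in place of phenyl on an amine nitrogen. The rest of compound 2 stays as it is. Among the compounds with values here, no measured pair shows this exchange, so the series offers no direct precedent and the expectation rests on the structural change alone. A small upward step in this assay is expected, near or within the scatter. The estimated change is a 1.5-fold higher number from compound 2 to compound 3 (0.18 log units; within the scatter) and remains uncertain until a reading exists. Compound 3 is estimated at 450000 nM with an expected range from 180000 nM to 1100000 nM in this series.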

Compound 3, solubility: 35100000 nM
Compound 3: the middle estimate sits 78-fold (1.89 log units) below what was measured, and the stated range ends below it.
By their numbers in this assay, from the lowest: compound 1; then compound 2; then compound 3.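

On the amine nitrogen whose other neighbour is a saturated chain carbon, the attached ring proves highly sensitive in this assay: pyridin-2-yl in place of phenyl gives a 120-fold higher number from compound 2 to compound 3 (2.07 log units; beyond the scatter). Within the data shown here, both earlier compounds carry a ring of carbon only at this place, so this is the first reading with a hetero atom there, and it shows that an exchange keeping the heavy-atom count unchanged and adding a single hydrogen-bond acceptor can produce a large step in this read-out. No accompanying measurement bears on the origin of the step, so the reading establishes its size and direction but gives no explanation for it.

Among these compounds, with only one exchange of this type in view, it remains open whether the step belongs to pyridin-2-yl in particular or would also appear with a pyridine ring joined through a different ring carbon, or with a pyrimidinyl ring. Also open, as far as these compounds go, is whether a methoxy group on the pyridin-2-yl ring would keep the reading near that of compound 3 or bring it back down.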